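This account rests on a few compounds, and the source may have more. Where it says the series, first, only, none or still open, it means among the compounds named here.

Compound 1 is `Cc1nc(-c2cccnc2)sc1-c1nnc(-c2cccnc2)o1` and in an ADME assay on THP-1 cells (Homo sapiens) for cytotoxicity, read by MTT assay (on this read-out higher numbers stand for lower toxicity in this test and lower numbers for higher toxicity in this test), compound 1 gives > 100 ug/mL, a limit of the assay rather than a number.
Compound 2 is `Cc1ccccc1-c1nnc(-c2sc(-c3cccnc3)nc2C)o1` and in this assay compound 2 gives > 100 ug/mL, again a limit.
Compound 3 is `Cc1nc(-c2cccnc2)sc1-c1nnc(Cc2ccccc2)o1` and in this assay compound 3 gives > 100 ug/mL, also a limit.

Compound 1 therefore stands only at a limit, and all three values sit at the same limit (the limit of > 100 ug/mL in this assay, at which 3 of the 3 values shown sit). The steps from compound 1 to its neighbours, a step that the two limits leave unreadable from compound 1 to compound 2 and a step that the two limits leave unreadable from compound 1 to compound 3, cannot be sized for that reason, and the same holds for a step that the two limits leave unreadable from compound 2 to compound 3.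

The unmeasured compound 4 is `Cc1nc(-c2cccnc2)sc1-c1nnc(-c2ccc(Cl)cc2)o1`. It differs from compound 1 as follows: 4-chlorophenyl in place of pyridin-3-yl on an aromatic carbon. Among the compounds with values here, the steps that bear on this change, those from compound 1 to compound 2 and to compound 3, both exchanged the pyridin-3-yl at this position for a carbon-only group without moving either compound away from the limit. No step beyond the scatter is therefore expected in this assay, and compound 4 is estimated to sit at 110 ug/mL, between 55 ug/mL and 220 ug/mL, with the step that the limit leaves unreadable from compound 1 to compound 4 expected to be unreadable as well.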

Compound 4, half-maximal cytotoxic concentration: > 100 ug/mL
Compound 4: no number, only a limit; the forecaster's own chance of this, stated with the estimate: 75%; the middle value lies beyond the limit too.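

In this assay compound 4 gives > 100 ug/mL, a limit and not a number. No step from compound 1, compound 2 or compound 3 to compound 4 can therefore be read: the limit of > 100 ug/mL in this assay, at which 4 of the 4 values shown sit.

The compounds shown leave open how far the true values of these four compounds differ from one another.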